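Hydroxy to methoxy on compound 1

The source may report more compounds than this note shows. Statements on the series, on what has been measured and on what is new or still open speak of the compounds shown alone.

Compound 1 (`O=C(/C=C/c1ccc(OCCCCCO[N+](=O)[O-])c(O)c1)OCCCCCO[N+](=O)[O-]`) is the starting point in a functional assay on NCI-H157 cells (Homo sapiens) for cytotoxicity, read by resazurin assay, with a stated time of 72 h; a lower number here means a stronger inhibitor, a higher number a weaker inhibitor. In that assay compound 1 gives > 50000 nM, which is a limit and not a number. Compound 2 (`O=C(/C=C/c1ccc(OCCCCCCO[N+](=O)[O-])c(O)c1)OCCCCCCO[N+](=O)[O-]`) gives > 50000 nM, which is also a limit. Going by the values given here, the evidence so far is the limit of > 50000 nM in this assay, at which 2 of the 2 values shown sit, and no numerical step between measured compounds is available. Compound 3 (`COc1cc(/C=C/C(=O)OCCCCCO[N+](=O)[O-])ccc1OCCCCCO[N+](=O)[O-]`) departs from compound 1 by a single change, methyl in place of hydrogen on an oxygen on an aromatic ring: hydroxy to methoxy, with methyl in place of hydrogen on an oxygen on an aromatic ring. No large step is expected in this assay because compound 1 stands at > 50000 nM as a limit. The expected change is a step that the limit leaves unreadable from compound 1 to compound 3. For compound 3 the estimated value is 60000 nM, with an expected range from 25000 nM to 150000 nM.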

Compound 3, half-maximal inhibitory concentration: > 50000 nM
Compound 3 was reported as a limit (the forecaster's own chance of this, stated with the estimate: 75%); the middle value does not contradict the limit.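

In this assay compound 3 gives > 50000 nM, which is a limit and not a number. Going by these compounds alone, compound 1 also stands at a limit, and no step from compound 1 to compound 3 can be read. The compounds shown leave open whether hydroxy to methoxy changes cytotoxicity in this assay at all.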